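Swapping tert-Butyl for 4-Methylbenzyl on the Shared Core

This account rests on a few compounds, and the source may have more. Where it says the series, first, only, none or still open, it means among the compounds named here.

Three compounds share one core and differ only in the group that sits on an aromatic carbon of that core. Compound 1 `O=C(O)c1ccccc1-c1ccc(CCc2ncc(C3CCCCC3)[nH]2)cc1` carries a cyclohexyl there, and in an in vitro functional assay on cells for agonist activity at Bombesin receptor subtype-3 (Mus musculus), read by luminescence and calcium flux (a lower number here means that less compound is needed, a higher number that more compound is needed for the effect), compound 1 gives 14.7 nM. Compound 2 `Cc1cccc(Cc2cnc(CCc3ccc(-c4ccccc4C(=O)O)cc3)[nH]2)c1` carries a 3-methylbenzyl; in this assay compound 2 gives 75 nM. Compound 3 `CC(C)(C)c1cnc(CCc2ccc(-c3ccccc3C(=O)O)cc2)[nH]1` carries a tert-butyl, and in this assay compound 3 gives 2750 nM, the highest number of the three, so compound 1 and compound 2 both needed less. The measured steps all run the same way: a 5.1-fold higher number from compound 1 to compound 2 (0.71 log units; beyond the scatter), a 190-fold higher number from compound 1 to compound 3 (2.27 log units; beyond the scatter) and a 37-fold higher number from compound 2 to compound 3 (1.56 log units; beyond the scatter).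

Compound 4 `Cc1ccc(Cc2cnc(CCc3ccc(-c4ccccc4C(=O)O)cc3)[nH]2)cc1` is the next move: 4-methylbenzyl in place of tert-butyl on an aromatic carbon. The step from compound 2 to compound 3 bears directly on it, as that step traded a methylbenzyl for the tert-butyl and was large; read in reverse it points to a large fall in the number. Among the compounds with values here, whether the methyl placed as in 4-methylbenzyl rather than as in 3-methylbenzyl matters, no measured pair can say. Compound 4 is therefore expected to show a 28-fold lower number from compound 3 to compound 4 (1.44 log units; beyond the scatter) in this assay. Compound 4 is estimated at 100 nM, within a range from 30 nM to 400 nM.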

Compound 4, half-maximal effective concentration: 162 nM
Beside the measured number, compound 4's estimate is 1.6-fold (0.21 log units) below it; the measured number falls inside the stated range.
By their numbers in this assay, from the lowest: compound 1; then compound 2; then compound 4; then compound 3.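

Moving the methyl from the 3-methylbenzyl to the 4-methylbenzyl gives a 2.2-fold higher number from compound 2 to compound 4 (0.33 log units; beyond the scatter) in this assay, a small step but the first measured sign that the methyl's placement on this group can shift the number. The a 17-fold lower number from compound 3 to compound 4 (1.23 log units; beyond the scatter) shows that the large gap between a methylbenzyl and the tert-butyl holds for both methylbenzyl compounds, so it does not depend on a single placement of the methyl, while an 11-fold higher number from compound 1 to compound 4 (1.04 log units; beyond the scatter) shows that, like compound 2, compound 4 still needs more compound than the cyclohexyl-bearing compound 1 does. Nothing measured here offers a reason for any of these differences.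

Going by these compounds, whether the methyl is needed at all stays open, as a plain benzyl group would show how either methylbenzyl compares with no methyl on that ring. Also open, on these data alone, is how a cyclopentyl group, or a piperidine ring with its amine nitrogen, would compare with the cyclohexyl of compound 1 on this aromatic carbon.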